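The compounds below may be only part of what the source reports. "The series", "measured", "known", "first", "only" and "open" are said of these compounds alone.

Three compounds have been measured in a functional assay on NCI-H322 cells (Homo sapiens) for cytotoxicity, read by MTT assay, with a stated time of 24 h; a higher number here means a weaker inhibitor, a lower number a stronger inhibitor:
Compound 1 `COc1ccc(/C=C\C(=O)O)c(OCc2cn(-c3ccccc3F)nn2)c1CC=C(C)C` gives 45600 nM.
Compound 2 `COc1ccc(/C=C\C(=O)O)c(OCc2cn(-c3cccc(C#N)c3)nn2)c1CC=C(C)C` gives 26500 nM.
Compound 3 `COc1ccc(/C=C\C(=O)O)c(OCc2cn(-c3ccc(C#N)cc3)nn2)c1CC=C(C)C` gives 18600 nM.

All three share one core and differ only in the aromatic group attached to an aromatic nitrogen of the five-membered ring with three nitrogens. Compound 3 has the lowest number of the three in this assay; its gap to compound 2 lies within the scatter, while its gap to compound 1 lies beyond it: a 2.5-fold lower number from compound 1 to compound 3 (0.39 log units; beyond the scatter). The other two steps are small: a 1.7-fold lower number from compound 1 to compound 2 (0.24 log units; within the scatter) and a 1.4-fold lower number from compound 2 to compound 3 (0.15 log units; within the scatter).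

Compound 4 `COc1ccc(/C=C\C(=O)O)c(OCc2cn(-c3nc4ccccc4s3)nn2)c1CC=C(C)C` carries a new group at that same place: 1,3-benzothiazol-2-yl in place of 4-cyanophenyl on an aromatic nitrogen. The three measured steps each swap one aromatic group on that nitrogen, and none of them moved the number by more than a modest amount. None of them involves a group resembling 1,3-benzothiazol-2-yl, so they bear on this step only loosely. The expectation in this assay is therefore a step of about the size of the scatter, with no clear direction. Compound 4 is expected to give 15000 nM, between 6000 nM and 40000 nM. This estimate means that a 1.2-fold lower number from compound 3 to compound 4 (0.09 log units; within the scatter) is expected.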

Compound 4, half-maximal inhibitory concentration: 23000 nM
Beside the measured number, compound 4's estimate is 1.5-fold (0.19 log units) below it, within the range that was stated.
By their numbers in this assay, from the lowest: compounds 3, 4, 2 and 1 (each within the scatter of the next, the first and the last beyond it).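

In this assay the 1,3-benzothiazol-2-yl group brings a five-membered aromatic ring with 2 hetero atoms, including a sulfur that no earlier group on this aromatic nitrogen carried, yet the number shows a 1.2-fold higher number from compound 3 to compound 4 (0.09 log units; within the scatter) and a 1.2-fold lower number from compound 2 to compound 4 (0.06 log units; within the scatter) and a 2.0-fold lower number from compound 1 to compound 4 (0.30 log units; within the scatter) without leaving the scatter in any of these steps. At this position, then, a group with two aromatic rings sits level with single substituted phenyl rings, and a nitrile is not needed to stay within the scatter of compound 3. No measurement at hand explains this result.

Every group shown on this nitrogen is aromatic, so the effect of a cyclohexyl ring, a short alkyl chain or a chain ending in an amine remains open. The shared core stays fixed throughout, which also leaves open what a methyl ester in place of its carboxylic acid would do.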